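Methoxy removal and solubility in phenoxy- and benzyloxyacetic acids

The compounds below may be only part of what the source reports. "The series", "measured", "known", "first", "only" and "open" are said of these compounds alone.

Measured compounds: compound 1 `COc1cc(OC)cc(OCC(=O)O)c1` with 242000 ug/mL; compound 2 `COc1cc(OCC(=O)O)cc(OC)c1OC` with 242000 ug/mL; compound 3 `COc1cc(COCC(=O)O)ccc1C` with 242000 ug/mL.

In an ADME assay for solubility (on this read-out higher numbers stand for higher solubility and lower numbers for lower solubility), compound 1 gives 242000 ug/mL and compound 2 gives 242000 ug/mL. The change between them is hydrogen in place of methoxy on an aromatic carbon, and the step it made is no change at the digits printed from compound 2 to compound 1 (within the scatter). Compound 3 stands level with both. The difference between the core of compound 3 and the core of compound 2 is not broken down here.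

Compound 4 `Cc1ccc(COCC(=O)O)cc1` has not been measured. The change from compound 3 to compound 4 is hydrogen in place of methoxy on an aromatic carbon. It is the same kind of change as from compound 2 to compound 1, not the same: the place is ortho to a methyl group and meta to a group of 6 heavy atoms, rather than ortho to two methoxy groups and para to a carboxymethoxy group.

In this assay the step from compound 3 to compound 4 is expected to be no change at the digits printed from compound 3 to compound 4 (within the scatter), resting on no change at the digits printed from compound 2 to compound 1 (within the scatter). Compound 4 is estimated at 242000 ug/mL.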

Compound 4, solubility: 242000 ug/mL
Estimate against measurement, compound 4: no gap at the digits printed; the range from low to high includes it.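

In this assay, among these compounds, putting hydrogen in place of methoxy on the core of compound 3 gave no change at the digits printed from compound 3 to compound 4 (within the scatter), and this step stands beside the earlier one on the other core: the same change on two cores in this assay, no change at the digits printed (within the scatter) from compound 2 to compound 1 and no change at the digits printed (within the scatter) from compound 3 to compound 4, 1.0-fold (0.00 log units) apart, within the scatter of two such steps On these two cores, then, the change carried across with no difference between the steps. This does not show that it would carry to further cores or to other places on the ring, and since neither step shows a change, it offers no size of effect to transfer.

The compounds shown leave open what an amine or a longer chain in place of the methoxy would give in this assay. They also leave open how the same change would read with an amide in place of the carboxylic acid.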